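Ethoxy in place of isopropylamino on a carbonyl carbon

The source may hold more compounds than are shown below. What is called first, only, known or untested is meant among the compounds shown, and "the series" means these compounds.

Measured so far:
- compound 1 `CC(C)NC(=O)[C@H]1CC[C@@H](n2/c(=N/C(=O)c3ccccc3)[nH]c3ccc(CN4CCCCC4)cc32)CC1` gives 203 mL.min-1.g-1 in an in vitro ADME assay on microsomes from liver (Homo sapiens) for metabolic stability; on this read-out higher numbers stand for fast clearance and lower numbers for slow clearance
- compound 2 `CC(C)NC(=O)[C@H]1CC[C@@H](n2/c(=N/C(=O)c3ccccc3)[nH]c3ccc(CN4CCC(C(C)(C)O)CC4)cc32)CC1` gives 40 mL.min-1.g-1 in this assay

Compound 1 has the higher number of the two. Going by the values given here, the only measured step runs down from it, with a 5.1-fold lower number from compound 1 to compound 2 (0.71 log units; beyond the scatter) on 1-hydroxy-1-methylethyl in place of hydrogen on a saturated ring carbon.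

Next in line is compound 3 `CCOC(=O)[C@H]1CC[C@@H](n2/c(=N/C(=O)c3ccccc3)[nH]c3ccc(CN4CCCCC4)cc32)CC1` with the change ethoxy in place of isopropylamino on a carbonyl carbon that reads as ethoxy in place of isopropylamino on a carbonyl carbon. The step to compound 2 was made at a different place, so it bears on this change only indirectly: it shows that one change in this series can move the number beyond the scatter. Among the compounds with values here, no measured pair covers the exchange itself, so compound 1 at 203 mL.min-1.g-1 serves as the anchor for the estimate.

The expected step is a 1.3-fold higher number from compound 1 to compound 3 (0.12 log units; within the scatter) and this estimate leans slightly upward without a step beyond the scatter being expected. Compound 3 is expected at 270 mL.min-1.g-1 with an estimated range from 120 mL.min-1.g-1 to 600 mL.min-1.g-1 in the measurement still to come.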

Compound 3, intrinsic clearance in microsomes: 222 mL.min-1.g-1
Estimate against measurement, compound 3: 1.2-fold (0.09 log units) above, and the stated range covers the measured number.
By their numbers in this assay, from the lowest: compound 2; then compounds 1 and 3 (each within the scatter of the next).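

In this assay the exchange of isopropylcarbamoyl for ethoxycarbonyl gives a 1.1-fold higher number from compound 1 to compound 3 (0.04 log units; within the scatter) and so stays within the scatter, which means that on this pair the group on the carbonyl carbon can change from isopropylamino to ethoxy, with the donor and acceptor counts changing as well, without a readable change in clearance. Going by these compounds alone, the only step beyond the scatter remains a 5.1-fold lower number from compound 1 to compound 2 (0.71 log units; beyond the scatter), which lies at a different place, so the series so far has one place where a single change moves the number and one where this single change does not. Nothing available explains why the number holds here, and no supporting data bear on this result.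

Still open, as far as these compounds go, is whether a carboxylic acid, a primary amide or a longer chain such as n-butoxy on the same carbonyl carbon would also stay within the scatter, since a single exchange cannot describe the whole position. Also open, from the compounds shown here alone, is whether 1-hydroxy-1-methylethyl would give a comparable step when ethoxy sits on the carbonyl carbon in place of isopropylamino.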